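A few compounds are considered here, and "the series" means these few. Any claim that something is new, unique, unknown or untested is made for them only; others in the source may bear on it.

Measured so far:
compound 1 `CCOc1ccc(-c2cccc(S(=O)(=O)N(C)C)c2)cc1`: 110000 nM
compound 2 `CCOc1ccc(-c2cccc(C(=O)OCCOC)c2)cc1`: 70000 nM

In an assay on COS-7 cells for inhibition of patatin-like phospholipase domain-containing protein 2 (Mus musculus) (on this read-out higher numbers stand for weaker inhibition and lower numbers for stronger inhibition), compound 2 shows the lower of the two numbers, but the step of a 1.6-fold lower number from compound 1 to compound 2 (0.20 log units; within the scatter) lies within the scatter, so compound 1 and compound 2 cannot be ordered on it. Compound 3 `CCOc1ccc(-c2cccc(C(=O)N3CCCC3)c2)cc1` carries the change (pyrrolidin-1-yl in place of 2-methoxyethoxy on a carbonyl carbon). Going by the values given here, no measured step touches this carbonyl substituent; the only step on record, a 1.6-fold lower number from compound 1 to compound 2 (0.20 log units; within the scatter), concerns a different group and was itself within the scatter, so it gives no direction for compound 3. The expectation for compound 3 in this assay is therefore a step of no change at the digits printed from compound 2 to compound 3 (within the scatter), that is, none beyond the scatter. The estimate for compound 3 is 70000 nM, with a range of 25000 nM to 200000 nM.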

Compound 3, half-maximal inhibitory concentration: 160000 nM
For compound 3 the middle estimate is 2.3-fold (0.36 log units) below the measured one; the measured number falls inside the stated range.
By their numbers in this assay, from the lowest: compounds 2, 1 and 3 (each within the scatter of the next, the first and the last beyond it).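

In this assay, going by these compounds alone, pyrrolidin-1-yl in place of 2-methoxyethoxy on the carbonyl carbon gives the only step on record beyond the scatter, and it is modest (a 2.3-fold higher number from compound 2 to compound 3 (0.36 log units; beyond the scatter)). The substituent on this carbonyl carbon therefore registers on this read-out, whereas (pyrrolidin-1-yl)carbonyl in place of dimethylsulfamoyl gives no separable result (a 1.5-fold higher number from compound 1 to compound 3 (0.16 log units; within the scatter)). No supporting data bear on the reason for this step.

Still open, from the compounds shown here alone, is whether a dimethylamino group or a hydroxyl, which would give a carboxylic acid, on this carbonyl carbon would separate from compound 2 or compound 3.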